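A few compounds are considered here, and "the series" means these few. Any claim that something is new, unique, unknown or untested is made for them only; others in the source may bear on it.

Compound 1 `O=C(CCc1cccc2c1B(O)OC2)Nc1ccccc1`: 230 nM
Compound 2 `O=C(CCc1cccc2c1B(O)OC2)Nc1ccc(I)cc1`: 33000 nM
Compound 3 `COc1ccccc1NC(=O)CCc1cccc2c1B(O)OC2`: not yet measured

Among the compounds with values here, in a functional assay on MDA-MB-231 cells (Homo sapiens) for antiproliferative activity, read by MTT assay, with a stated time of 72 h (a lower number here means a stronger inhibitor, a higher number a weaker inhibitor), compound 1 gives 230 nM, the lower of the two numbers measured so far, while compound 2 gives 33000 nM. Compound 3 keeps the core of compound 1 and differs from it in one place: methoxy in place of hydrogen on an aromatic carbon. This is methoxy in place of hydrogen on an aromatic carbon, ortho to a large group.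

Within the data shown here, only one measured step bears on this change. Iodo in place of hydrogen on an aromatic carbon gave a 140-fold higher number from compound 1 to compound 2 (2.16 log units; beyond the scatter), a large step beyond the scatter. That single step involves a different group, so it gives only a rough guide to direction and size. Going by compound 2 at 33000 nM, a higher number is expected in this assay for compound 3, though by a smaller step, and a result close to compound 1 cannot be excluded. The estimate corresponds to an expected 6.5-fold higher number from compound 1 to compound 3 (0.81 log units; beyond the scatter). For compound 3 the estimated value is 1500 nM, with an expected range from 200 nM to 12000 nM.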

Compound 3, half-maximal inhibitory concentration: 930 nM
Compound 3: middle estimate off by 1.6-fold (0.21 log units), on the high side, and the stated range covers the measured number.
By their numbers in this assay, from the lowest: compound 1; then compound 3; then compound 2.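

In this assay, methoxy in place of hydrogen on an aromatic carbon, ortho to a large group, gives a 4.0-fold higher number from compound 1 to compound 3 (0.61 log units; beyond the scatter) and so supplies a second substitution on this six-membered aromatic ring to set beside the iodo change, which gave a 140-fold higher number from compound 1 to compound 2 (2.16 log units; beyond the scatter) in the same assay. Both replacements of hydrogen raise the number, with no listed compound going against this, but the methoxy step is modest where the iodo step is large, so a substituent on this ring does not have to cost as much as the first pair suggested. No measurement shown offers an explanation for either rise or for the difference in their size.

The compounds shown leave open whether the modest step belongs to the methoxy group itself or to its place on the ring, since methoxy appears at only this one place and no second group stands there for comparison. An amine, a hydroxyl group or a fluorine atom at this same place, or methoxy moved elsewhere on the ring, would separate the group from the place.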